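The source may hold more compounds than are shown below. What is called first, only, known or untested is meant among the compounds shown, and "the series" means these compounds.

Measured compounds:
Compound 1, `Oc1ccccc1-c1cc(-c2ccco2)cc(-c2ccccc2O)n1`: in a functional assay on HeLa cells (Homo sapiens) for cytotoxicity, read by CCK-8 assay (on this read-out lower numbers stand for stronger inhibition and higher numbers for weaker inhibition), compound 1 gives > 50000 nM, which is a limit of the assay and not a number.
Compound 2, `Oc1ccc(-c2cc(-c3ccco3)cc(-c3ccccc3O)n2)cc1`: in this assay compound 2 gives > 50000 nM, again a limit of the assay and not a number.

Compound 2 therefore stands at the limit of this assay, and nothing in the numbers separates it from compound 1. Going by the values given here, the only measured step, a step that the two limits leave unreadable from compound 1 to compound 2, cannot be read in size or direction, as both of its ends sit at the limit of > 50000 nM in this assay, at which 2 of the 2 values shown sit.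

The next compound, compound 3, `Oc1ccc(-c2cc(-c3ccccn3)cc(-c3ccccc3O)n2)cc1`, differs from compound 2 by pyridin-2-yl in place of furan-2-yl on an aromatic carbon. Among the compounds with values here, the one measured step bears on it only in the sense that it shows the assay window has not been entered by either neighbour, so no step of any particular size or direction beyond the scatter can be expected in this assay from this change.

Compound 3 is accordingly expected to give about 60000 nM in this assay, with a range from 20000 nM to 200000 nM, most probably reported again as a limit. The step this estimate implies, a step that the limit leaves unreadable from compound 2 to compound 3, is expected to be unreadable in the same way.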

Compound 3, half-maximal inhibitory concentration: > 50000 nM
Compound 3 was reported as a limit; the forecaster's own chance of this, stated with the estimate: 80%; the middle value is on the limit's open side.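

In this assay compound 3 gives > 50000 nM and this is again a limit of the assay and not a number. Going by these compounds alone, no step from compound 2 to compound 3 can therefore be read in size or direction, as both ends sit at the same limit: the limit of > 50000 nM in this assay, at which 3 of the 3 values shown sit.

The compounds shown leave open how furan-2-yl and pyridin-2-yl compare inside the readable range.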